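Shrinking a Sulfonamide Substituent: Tert-Butyl to Ethyl

A few compounds are considered here, and "the series" means these few. Any claim that something is new, unique, unknown or untested is made for them only; others in the source may bear on it.

Compound 1, `CCOC(=O)[C@@H]1CCCN(S(=O)(=O)c2ccc(S(=O)(=O)N(CC)CC)cn2)C1`, gives > 10000 nM in a functional assay on MIA PaCa-2 cells (Homo sapiens) for inhibition, read by MTT assay, with a stated time of 3 days (on this read-out lower numbers stand for stronger inhibition and higher numbers for weaker inhibition), which is a limit of the assay.
Compound 2, `CC(C)c1noc(N2CCN(C(=O)[C@@H]3CCCN(S(=O)(=O)c4ccc(S(=O)(=O)NC(C)(C)C)cc4)C3)CC2)n1`, gives > 10000 nM in this assay, again a limit.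
Compound 3, `CCOC(=O)[C@@H]1CCCN(S(=O)(=O)c2ccc(S(=O)(=O)N(C)C)cc2)C1`, gives > 10000 nM in this assay, also a limit.

None of the three measured compounds yields a number in this assay; each result is only a limit. Compound 2 therefore stands exactly where the other two stand, at the limit of > 10000 nM in this assay, at which 3 of the 3 values shown sit, and no ranking among them is possible.

Compound 4, `CCNS(=O)(=O)c1ccc(S(=O)(=O)N2CCC[C@@H](C(=O)N3CCN(c4nc(C(C)C)no4)CC3)C2)cc1`, is compound 2 with one change: ethyl in place of tert-butyl on a sulfonamide nitrogen. Within the data shown here, no pair of measured compounds differs in just one place, so no measured step shows what such a swap does here. With compound 2 at > 10000 nM, a limit, there is no measured number from which a shift could be read.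

Compound 4 is expected to remain at or near the limit, estimated at 15000 nM, within 5000 nM to 50000 nM. The expected step that the limit leaves unreadable from compound 2 to compound 4 is none beyond the scatter.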

Compound 4, half-maximal inhibitory concentration: > 10000 nM
Compound 4 gave a limit, no number; the forecaster's own chance of this, stated with the estimate: 85%; the middle value lies beyond the limit too.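

Compound 2 and compound 4 each give only a limit, not a number, so no step can be read for ethyl in place of tert-butyl: the limit of > 10000 nM in this assay, at which 4 of the 4 values shown sit. The compounds shown leave open what this swap does, and which structures would give a measurable value in this assay.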